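Amide ring swap on compound 3: what clearance follows?

A few compounds are considered here, and "the series" means these few. Any claim that something is new, unique, unknown or untested is made for them only; others in the source may bear on it.

Measured so far:
compound 1 `Cc1ccc(C(=O)Nc2cn3ncnc3c(O[C@H]3CCN(C(=O)CC(C(F)(F)F)C(F)(F)F)[C@@H](C)C3)c2C)cn1` — 10 mL.min-1.g-1
compound 2 `Cc1ccc(C(=O)Nc2cn3ncnc3c(CN3CCN(C(=O)C4CCCC4)[C@@H](C)C3)c2C)cn1` — 32 mL.min-1.g-1
compound 3 `Cc1ccc(C(=O)Nc2cn3ncnc3c(CN3CCN(C(=O)C4CCOCC4)[C@@H](C)C3)c2C)cn1` — < 10 mL.min-1.g-1 (a limit)

In an ADME assay on microsomes from liver (Homo sapiens) for metabolic stability (on this read-out lower numbers stand for slow clearance and higher numbers for fast clearance), compound 1 gives 10 mL.min-1.g-1 and compound 2 gives 32 mL.min-1.g-1. Compound 3 reaches only the limit of this assay, < 10 mL.min-1.g-1, so its number is not fixed (the limit of < 10 mL.min-1.g-1 in this assay, at which 1 of the 3 values shown sits). Among the compounds with values here, the one measured step that bears on the next change is an at least 3.2-fold lower number from compound 2 to compound 3 (0.50 log units; beyond the scatter). Compound 4 `Cc1ccc(C(=O)Nc2cn3ncnc3c(CN3CCN(C(=O)C4CCC(F)(F)C4)[C@@H](C)C3)c2C)cn1` differs from compound 3 by 3,3-difluorocyclopentyl in place of oxan-4-yl on a carbonyl carbon. Because an at least 3.2-fold lower number from compound 2 to compound 3 (0.50 log units; beyond the scatter) went downward when oxan-4-yl replaced cyclopentyl, the return to a carbon-only five-membered ring, now 3,3-difluorocyclopentyl, is expected to move the number upward by an at least 1.5-fold higher number from compound 3 to compound 4 (0.17 log units; that floor lies within the scatter), though probably not back to the level of compound 2. Compound 4 is therefore estimated at 15 mL.min-1.g-1, with a range of 7 mL.min-1.g-1 to 35 mL.min-1.g-1.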

Compound 4, intrinsic clearance in microsomes: < 10 mL.min-1.g-1
Compound 4 gave a limit, no number; the forecaster's own chance of this, stated with the estimate: 30%; middle value at least 1.5-fold (0.17 log units) away from the limit.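

In this assay compound 4 reaches a limit, < 10 mL.min-1.g-1, and not a number. Putting 3,3-difluorocyclopentyl in place of cyclopentyl on the carbonyl carbon gives an at least 3.2-fold lower number from compound 2 to compound 4 (0.50 log units; beyond the scatter), so at this place a ring of carbon only can also give a lower number, as the oxan-4-yl group of compound 3 did. The step between compound 3 and compound 4 cannot be read, and the two cannot be ordered: the limit of < 10 mL.min-1.g-1 in this assay, at which 2 of the 4 values shown sit.

As far as these compounds go, what remains open is how far past the limit either compound lies. Also open, from the compounds shown here alone, is whether a 4,4-difluorocyclohexyl group or an open alkyl chain on this carbonyl carbon would give a similar result.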